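Working notes: benzyl to 3-methoxyphenyl from compound 1

The source may report more compounds than this note shows. Statements on the series, on what has been measured and on what is new or still open speak of the compounds shown alone.

Compound 1 `CCOC(=O)CN(Cc1ccccc1)c1nc(NCc2ccccc2)ncc1[N+](=O)[O-]` is recorded in a functional assay on A549 cells (Homo sapiens) for antiproliferative activity, read by MTT assay, with a stated time of 48 h (on this read-out higher numbers stand for weaker inhibition and lower numbers for stronger inhibition), only as a limit of the assay, > 100000 nM. Compound 3 `COC(=O)CN(C)c1nc(Nc2ccccc2)ncc1[N+](=O)[O-]` also sits at the limit in this assay, > 100000 nM. For the measured compounds named here, compound 2 `CCOC(=O)CNc1nc(NCc2ccccc2)ncc1[N+](=O)[O-]` is the one member with a number in this assay, 74400 nM. Going by the values given here, the single measured step is an at least 1.3-fold lower number from compound 1 to compound 2 (0.12 log units; that floor lies within the scatter), and it begins at the limit of > 100000 nM in this assay, at which 2 of the 3 values shown sit, so it fixes no clear size.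

Compound 4 `CCOC(=O)CN(Cc1ccccc1)c1nc(Nc2cccc(OC)c2)ncc1[N+](=O)[O-]` is not yet measured; it differs from compound 1 by 3-methoxyphenyl in place of benzyl on a nitrogen on an aromatic ring. Among the compounds with values here, no measured step exchanges benzyl for an aryl group, so the series gives no direction for this change; the only known step, an at least 1.3-fold lower number from compound 1 to compound 2 (0.12 log units; that floor lies within the scatter), removes benzyl altogether and stays within the scatter. Compound 3, which carries an aryl group in place of benzyl along with other differences, is itself at the limit. For compound 4 the expected step of a number no higher from compound 1 to compound 4 (the limit leaves the size open) is accordingly none beyond the scatter. Compound 4 is estimated at 100000 nM in this assay, with a range from 30000 nM to 400000 nM, and a substantial chance that only a limit is reported again.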

Compound 4, half-maximal inhibitory concentration: > 100000 nM
Compound 4 ended at the assay's limit; the forecaster's own chance of this, stated with the estimate: 60%; the middle value sits exactly at the limit.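

No step can be read from compound 1 to compound 4 in this assay, as both are recorded only as limits: the limit of > 100000 nM in this assay, at which 3 of the 4 values shown sit.

The compounds shown leave open whether 3-methoxyphenyl in place of benzyl changes the read-out at all, and in which direction.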